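The source may hold more compounds than are shown below. What is called first, only, known or untested is meant among the compounds shown, and "the series" means these compounds.

Measured so far:
- Compound 1, `COc1ccc(CNc2nc(SC)nc3ccccc23)cc1`: 96200 nM
- Compound 2, `C[Se]c1nc(N)c2cccnc2n1`: 90800 nM
- Compound 3, `COc1ccc(CNc2nc(S)nc3ccccc23)cc1`: 32500 nM

These three compounds were tested in an ADME assay on BEAS-2B cells (Homo sapiens) for cytotoxicity, read by MTT assay, with a stated time of 72 h; a lower number here means a stronger inhibitor of growth, a higher number a weaker inhibitor of growth. Compound 1 gives the highest number of the three; compound 2 sits within the scatter of it, so the two cannot be told apart, while compound 3 lies beyond the scatter below it. Within the data shown here, the only step between neighbours here is a 3.0-fold lower number from compound 1 to compound 3 (0.47 log units; beyond the scatter), which changes the sulfur substituent on the shared core.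

Compound 4, `CSc1ccc(CNc2nc(SC)nc3ccccc23)cc1`, has not yet been tested. It differs from compound 1 by methylsulfanyl in place of methoxy on an aromatic carbon. Among the measured compounds shown here, this change sits on the benzyl ring, away from the sulfur where the one measured step occurred, so no measured step bears on it directly; the step from compound 1 to compound 3 says nothing about the benzyl ring, and compound 2 has a different core altogether. With no guidance from the data, the expected step in this assay is none beyond the scatter, a 1.1-fold lower number from compound 1 to compound 4 (0.03 log units; within the scatter). Compound 4 is therefore estimated at 90000 nM, with a range from 40000 nM to 200000 nM.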

Compound 4, concentration for total growth inhibition: 59100 nM
Compound 4: the middle estimate sits 1.5-fold (0.18 log units) above what was measured; low and high end bracket the measured number.
By their numbers in this assay, from the lowest: compounds 3, 4, 2 and 1 (each within the scatter of the next, the first and the last beyond it).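

Compound 1 and compound 4 share the same core and differ only on an aromatic carbon of a six-membered aromatic ring of carbon only, para to a large group. This is a part of the structure that the earlier step, at the sulfur on the core, did not touch. Here, in this assay, methylsulfanyl in place of methoxy gives a 1.6-fold lower number from compound 1 to compound 4 (0.21 log units; within the scatter), so this exchange leaves the two compounds indistinguishable. The measurements offer no explanation for this result.

As far as these compounds go, whether a different group at this position, such as an amine or a carboxylic acid, would shift the number beyond the scatter remains open. It is also unknown whether methylsulfanyl at this position would give a similar result on the core of compound 3, with its free hydrogen on sulfur.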